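This account rests on a few compounds, and the source may have more. Where it says the series, first, only, none or still open, it means among the compounds named here.

Measured so far:
- compound 1, `COCCNC(=O)/C=C/c1cnc(Nc2ccc(C#N)cc2)nc1Oc1c(C)cc(C#N)cc1C`: > 213 nM
- compound 2, `Cc1cc(C#N)cc(C)c1Oc1nc(Nc2ccc(C#N)cc2)ncc1/C=C/C(=O)N1CCN(C(=O)C(F)(F)F)CC1`: > 174 nM

In an ADME assay on TZM cells (Homo sapiens) for cytotoxicity, with a stated time of 1 days (on this read-out lower numbers stand for higher toxicity in this test and higher numbers for lower toxicity in this test), compound 1 gives > 213 nM, which is a limit of the assay and not a number. Compound 2 gives > 174 nM in this assay, also a limit. Among the compounds with values here, the one measured step, a step that the two limits leave unreadable from compound 1 to compound 2, therefore has no readable size: both ends sit at a limit, as the limit of > 174 nM in this assay, at which 1 of the 2 values shown sits, and the limit of > 213 nM in this assay, at which 1 of the 2 values shown sits, show.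

Compound 3, `Cc1cc(C#N)cc(C)c1Oc1nc(Nc2ccc(C#N)cc2)ncc1/C=C/C(=O)NCCN1CCN(S(C)(=O)=O)CC1`, differs from compound 1 by 4-(methylsulfonyl)piperazin-1-yl in place of methoxy on a saturated chain carbon, two bonds along the chain from an amide-type nitrogen. Within the data shown here, no measured step covers this change, and the step from compound 1 to compound 2, which alters the same side of the amide, cannot tell how far any such change moves this read-out. For compound 3 the step that the limit leaves unreadable from compound 1 to compound 3 is therefore expected to stay within the usual scatter, and most likely the assay will again report only a limit. Compound 3 is estimated at 250 nM, within 120 nM to 1200 nM.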

Compound 3, half-maximal cytotoxic concentration: > 166 nM
Compound 3: only a limit was reported; the forecaster's own chance of this, stated with the estimate: 85%; the middle value lies beyond the limit too.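

Within the data shown here, compound 1 and compound 3 both stand at a limit in this assay, so no step between them can be read. The compounds shown leave open where the true cytotoxic concentration of compound 1, compound 2 and compound 3 lies, and whether changing the amide substituent shifts it.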